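Moving the halogen round the sulfonyl-linked phenyl ring

This account rests on a few compounds, and the source may have more. Where it says the series, first, only, none or still open, it means among the compounds named here.

Compound 1 `CC(O)(C(=O)Nc1ccc(S(=O)(=O)c2ccccc2F)cc1)C(F)(F)F` gives 1300 nM in a functional assay (Cavia porcellus) with sulfonylurea receptors; K-ATP channels (Homo sapiens) as the target; a higher number here means a weaker inhibitor, a lower number a stronger inhibitor. Compound 2 `CC(O)(C(=O)Nc1ccc(S(=O)(=O)c2ccccc2Cl)cc1)C(F)(F)F` gives 2300 nM in this assay. Compound 3 `CC(O)(C(=O)Nc1ccc(S(=O)(=O)c2cccc(Cl)c2)cc1)C(F)(F)F` gives 10000 nM in this assay.

Of these three numbers, compound 3 shows the highest, so it is the weakest inhibitor of the set: going a 7.7-fold higher number from compound 1 to compound 3 (0.89 log units; beyond the scatter) and a 4.3-fold higher number from compound 2 to compound 3 (0.64 log units; beyond the scatter) are both modest losses beyond the scatter, while a 1.8-fold higher number from compound 1 to compound 2 (0.25 log units; within the scatter) stays within it. Compound 4 `CC(O)(C(=O)Nc1ccc(S(=O)(=O)c2ccc(Br)cc2)cc1)C(F)(F)F` carries the change (4-bromophenyl in place of 3-chlorophenyl on a sulfonyl sulfur). Among the measured compounds shown here, no measured pair has a halogen at this position of the ring, so the measured steps only show that swapping fluoro for chloro at one position hardly matters, while shifting the halogen to another position cost a modest amount. On these data alone, the new position is untested, and the step from compound 3 could go either way. The step of a 1.7-fold lower number from compound 3 to compound 4 (0.22 log units; within the scatter) is therefore estimated as small and uncertain. Compound 4 is expected to give about 6000 nM in this assay, within a range from 1500 nM to 25000 nM.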

Compound 4, half-maximal inhibitory concentration: > 30000 nM
Compound 4: no number, only a limit; the forecaster's own chance of this, stated with the estimate: 20%; middle value at least 5.0-fold (0.69 log units) away from the limit.
By their numbers in this assay, from the lowest: compounds 1 and 2 (each within the scatter of the next); then compound 3. At a limit, above all of these: compound 4.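

Compound 4 gives no number in this assay, only a limit: the limit of > 30000 nM in this assay, at which 1 of the 4 values shown sits. Even so, the steps can be read as lower bounds, and they show that this change costs clearly more than the earlier ones: an at least 3.0-fold higher number from compound 3 to compound 4 (0.47 log units; beyond the scatter), an at least 13-fold higher number from compound 2 to compound 4 (1.11 log units; beyond the scatter) and an at least 23-fold higher number from compound 1 to compound 4 (1.36 log units; beyond the scatter). The 4-bromophenyl group thus sits at the weak end of these four compounds, although 4-bromophenyl differs from 3-chlorophenyl in both the halogen and its place on the ring, so these steps cannot show which of the two matters.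

On these data alone, how far compound 4 lies past its limit stays open, as does the separate share of the bromine and of its place. The compounds shown also leave open how an amine or a carboxylic acid in place of the halogen on this ring would read in this assay.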